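This account rests on a few compounds, and the source may have more. Where it says the series, first, only, none or still open, it means among the compounds named here.

Measured so far:
Compound 1 `O=C1C=C(NCc2ccccc2)C(=O)c2c1nc1n2[C@H]2OC[C@@H](O)[C@H]2OC1`: > 8000 nM (a limit)
Compound 2 `Cc1ccc(NC2=CC(=O)c3c(nc4n3[C@H]3OC[C@@H](O)[C@H]3OC4)C2=O)cc1C`: 4950 nM
Compound 3 `CCOc1ccc(NC2=CC(=O)c3c(nc4n3[C@H]3OC[C@@H](O)[C@H]3OC4)C2=O)cc1`: > 4000 nM (a limit)

In a functional assay on MCF7 cells (Homo sapiens) for inhibition, read by sulforhodamine B assay (a lower number here means a stronger inhibitor, a higher number a weaker inhibitor), compound 1 gives only a limit, > 8000 nM; where it truly stands is not known. Compound 2 gives 4950 nM. For compound 3 the reading is a limit, > 4000 nM, so the step that the limit leaves unreadable from compound 2 to compound 3 cannot be sized. Compound 4 `COc1cccc(NC2=CC(=O)c3nc4n(c3C2=O)[C@H]2OC[C@@H](O)[C@H]2OC4)c1` differs from compound 1 by 3-methoxyphenyl in place of benzyl on an amine nitrogen. Among the measured compounds shown here, no measured step matches this change, and the one measured step is unreadable, so the direction and size are open. Compound 4 is expected at 6000 nM, between 2000 nM and 20000 nM. The step from compound 1 to compound 4 is estimated as an at least 1.3-fold lower number from compound 1 to compound 4 (0.12 log units; that floor lies within the scatter).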

Compound 4, half-maximal inhibitory concentration: > 4000 nM
Compound 4 ended at the assay's limit (the forecaster's own chance of this, stated with the estimate: 50%); the middle value is on the limit's open side.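

Compound 1 and compound 4 are both reported only as limits, so the step between them cannot be read. From the compounds shown here alone, whether benzyl or 3-methoxyphenyl on the amine nitrogen gives the stronger inhibitor stays open.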